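Ring Contraction at the Amine of Compound 2

The source may hold more compounds than are shown below. What is called first, only, known or untested is meant among the compounds shown, and "the series" means these compounds.

Measured compounds:
compound 1 `Cc1cccc(C)c1-c1cccc(COc2ccc3c(c2)OCC3CC(=O)O)c1`: 74.4%
compound 2 `O=C(O)CC1COc2cc(OCc3cccc(N4CCCCC4)c3)ccc21`: 50.3%

In a functional assay on CHO cells for agonist activity at Free fatty acid receptor 1 (Homo sapiens), read by FLIPR and calcium flux, with a stated time of 90 s, tested at 300 nM (on this read-out higher numbers stand for a stronger effect at the one concentration tested and lower numbers for a weaker effect), compound 1 gives 74.4%, and compound 2 gives 50.3%. Going by the values given here, the only measured step, a number 24.1 percentage points lower from compound 1 to compound 2 (beyond the scatter), exchanges an aromatic group for a saturated amine ring. Compound 2 therefore stands as the lower of the two numbers, and its nearest neighbour is compound 1.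

Compound 3 `O=C(O)CC1COc2cc(OCc3cccc(N4CCCC4)c3)ccc21` differs from compound 2 in one place: pyrrolidin-1-yl in place of piperidin-1-yl on an aromatic carbon. Among the compounds with values here, no measured step swaps one saturated amine ring for another of different size, so the single known step bears on this change only loosely, as a reminder that this position tolerates a nitrogen ring attached to the aromatic carbon. Nothing in the data points to a direction, and the step is expected to stay within the scatter.

Compound 3 is accordingly estimated at 47%, with a range from 27% to 67%. The expected step is a number 3.3 percentage points lower from compound 2 to compound 3 (within the scatter).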

Compound 3, a percentage reported as activity, at one concentration (the size of the read-out at that concentration, not a potency): 56.3%
Estimate against measurement, compound 3: 9.3 percentage points below; the range from low to high includes it.
By their numbers in this assay, from the lowest: compounds 2 and 3 (each within the scatter of the next); then compound 1.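

In this assay, the exchange of the saturated amine ring leaves the two compounds within the scatter of each other (a number 6 percentage points higher from compound 2 to compound 3 (within the scatter)), so at this aromatic carbon, meta to a large group, the read-out does not separate piperidin-1-yl from pyrrolidin-1-yl. The distance from the 2,6-dimethylphenyl group remains beyond the scatter with pyrrolidin-1-yl as well (a number 18.1 percentage points lower from compound 1 to compound 3 (beyond the scatter)), which means that this gap does not depend on which of the two saturated amine rings is present. No evidence is available on what lies behind these numbers.

Going by these compounds, it remains open whether a morpholine ring, an azetidine ring or an open-chain dimethylamino group would stay with these two rings or come closer to compound 1. Also open, on these data alone, is how an unsubstituted phenyl group would read at this position.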